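This account rests on a few compounds, and the source may have more. Where it says the series, first, only, none or still open, it means among the compounds named here.

Measured so far in a functional assay on NALM-6 cells (Homo sapiens) for cytotoxicity, read by luminescence and CellTiter-Glo, with a stated time of 3 days; on this read-out higher numbers stand for weaker inhibition and lower numbers for stronger inhibition:
compound 1, `O=C(Nc1ccc(Br)c(Cl)c1)c1cc(F)ccc1O` — compound 1 gives 1250 nM
compound 2, `O=C(Nc1ccc(Cl)c(Cl)c1)c1cc(F)ccc1O` — compound 2 gives 1370 nM
compound 3, `O=C(Nc1ccc(Cl)cc1Cl)c1cc(F)ccc1O` — compound 3 gives 1620 nM

Compound 3 carries the highest of the three numbers, yet its gaps to compound 2 and to compound 1 both lie within the scatter, so the three compounds stand level on this read-out. Compound 4, `O=C(Nc1ccc([N+](=O)[O-])cc1Cl)c1cc(F)ccc1O`, differs from compound 3 in one place: nitro in place of chloro on an aromatic carbon. Going by the values given here, no measured step matches this change. Among the compounds with values here, the single measured step, a 1.1-fold higher number from compound 1 to compound 2 (0.04 log units; within the scatter), exchanges one halogen for another and stays within the scatter, so it offers no guide to a nitro entering. With nothing to point either way, the expected step of a 1.1-fold higher number from compound 3 to compound 4 (0.05 log units; within the scatter) is none beyond the scatter. Compound 4 is therefore estimated at 1800 nM, with a range from 700 nM to 4500 nM.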

Compound 4, half-maximal inhibitory concentration: 910 nM
Beside the measured number, compound 4's estimate is 2.0-fold (0.30 log units) above it, and the stated range covers the measured number.
By their numbers in this assay, from the lowest: compounds 4, 1, 2 and 3 (each within the scatter of the next).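

In this assay, nitro in place of chloro gives a 1.8-fold lower number from compound 3 to compound 4 (0.25 log units; within the scatter), so the two compounds stand level. The earlier compounds shown here compared only halogens, whereas here a nitro of 3 heavy atoms, with 2 hydrogen-bond acceptors, sits on the aromatic carbon para to a large group and the number stays within the scatter of the chloro compound. No measurement at hand accounts for this result. The compounds shown leave open whether an amine or a carboxylic acid at this place would also stay level, or would move the number beyond the scatter.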